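Fluorine Additions to Carbamate Anilines, Read-Out Level So Far

A few compounds are considered here, and "the series" means these few. Any claim that something is new, unique, unknown or untested is made for them only; others in the source may bear on it.

compound 1 `CC(C)=CCC1Cc2c(OC(=O)Nc3ccc(F)cc3)cc(=O)n(CCCO)c2CC1(C)C`: 0%
compound 2 `CC(C)=CCC1Cc2c(OC(=O)Nc3ccc(F)c(F)c3)cc(=O)n(CCCO)c2CC1(C)C`: 0%
compound 3 `CC(C)=CCC/C(C)=C/CC1Cc2c(OC(=O)Nc3ccccc3F)cc(=O)n(CCCO)c2CC1(C)C`: 0%

Three carbamates built on related cores were tested in a functional assay on PANC-1 cells (Homo sapiens) for inhibition, read by MTT assay, with a stated time of 24 h, tested at 10 uM; a higher number here means more inhibition at the concentration tested (going by the name of the read-out), a lower number less inhibition. Compound 1 gives 0%, compound 2 gives 0% and compound 3 gives 0%. The change fluoro in place of hydrogen on an aromatic carbon made a step of no change at the digits printed from compound 1 to compound 2 (within the scatter). How the core of compound 3 differs from that of compound 1 is not broken down here; the two values simply sit level within the scatter.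

Compound 4 `CC(C)=CCC/C(C)=C/CC1Cc2c(OC(=O)Nc3ccc(F)cc3F)cc(=O)n(CCCO)c2CC1(C)C` is reached from compound 3 by fluoro in place of hydrogen on an aromatic carbon. This is the same kind of change as that from compound 1 to compound 2, though the surroundings differ: there the entering fluoro sat ortho to a fluoro group and meta to a large group, here it sits meta to a fluoro group and para to a large group. In this assay a step of no change at the digits printed from compound 3 to compound 4 (within the scatter) is expected from compound 3 to compound 4, because no change at the digits printed from compound 1 to compound 2 (within the scatter) showed the earlier fluoro addition leaving the read-out flat and because compound 3 itself gives 0%. The estimate for compound 4 is therefore 0%, between 0% and 10%.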

Compound 4, a percentage reported as inhibition, at one concentration (the size of the read-out at that concentration, not a potency): 15.6%
Compound 4: middle estimate off by 15.6 percentage points, on the low side; the measured number lies above the stated range.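

In this assay, fluoro in place of hydrogen on the aromatic carbon gave a number 15.6 percentage points higher from compound 3 to compound 4 (beyond the scatter) on the core of compound 3, where the entering fluoro sits meta to a fluoro group and para to a large group. Set beside the earlier step on the core of compound 1, the result shows that this change did not carry over as a flat read-out from one core to the other: the same change on two cores in this assay, no change at the digits printed (within the scatter) from compound 1 to compound 2 and a number 15.6 percentage points higher (beyond the scatter) from compound 3 to compound 4, 15.6 percentage points apart, beyond the scatter of two such steps. It does not show whether the core or the place of the entering fluoro accounts for the gap, since the two steps differ in both, and one pair on each core gives no general rule for the series.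

The compounds shown leave open whether a 2,4-difluorophenyl group would also lift the read-out on the core of compound 1. They also leave open whether a chloro or a methoxy group entering at the same place on the core of compound 3 would behave as fluoro does.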